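A Second Chloro on the Aryl Ring of Compound 3

This account rests on a few compounds, and the source may have more. Where it says the series, first, only, none or still open, it means among the compounds named here.

Measured so far:
Compound 1, `N#C/C(=C\N1CCN(C(=O)c2ccco2)C1=S)C(=O)Nc1ccc(Cl)cc1`: 16700 nM
Compound 2, `N#C/C(=C\N1CCN(C(=O)c2ccco2)C1=S)C(N)=O`: 18700 nM
Compound 3, `O=CN1CCN(c2ccc(Cl)cc2)C1=S`: 14800 nM

In a functional assay on NCI-H522 cells (Homo sapiens) for inhibition, read by sulforhodamine B assay, with a stated time of 48 h (a higher number here means a weaker inhibitor of growth, a lower number a stronger inhibitor of growth), the three compounds give numbers that sit within the usual scatter of one another; on the bare figures compound 3 has the lowest number, with compound 1 nearest and compound 2 furthest. For the measured compounds named here, the one step between measured compounds that differ in a single place is a 1.1-fold higher number from compound 1 to compound 2 (0.05 log units; within the scatter), where a hydrogen replaces a 4-chlorophenyl on an amide-type nitrogen; it lies within the scatter.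

Compound 4, `O=CN1CCN(c2ccc(Cl)c(Cl)c2)C1=S`, differs from compound 3 by chloro in place of hydrogen on an aromatic carbon. Going by the values given here, no measured step adds a chloro to an aromatic ring, so the only guide is the general picture: the changes seen so far, including the removal of a whole chlorinated ring, moved the numbers by no more than the scatter. A single added chloro is a smaller change than that, so compound 4 is expected to stay near compound 3 in this assay, with the step of a 1.1-fold lower number from compound 3 to compound 4 (0.06 log units; within the scatter) estimated to fall inside the scatter. The number expected for compound 4 is 13000 nM, within a range from 5000 nM to 35000 nM.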

Compound 4, concentration for 50% growth inhibition: 4900 nM
The estimate for compound 4 lay 2.7-fold (0.42 log units) above the measured number, outside the stated range (below it).
By their numbers in this assay, from the lowest: compound 4; then compounds 3, 1 and 2 (each within the scatter of the next).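

Compound 4 shows that this position on the aromatic ring can matter: in this assay, placing a chloro ortho to a chloro group and meta to a group of 8 heavy atoms gives a 3.0-fold lower number from compound 3 to compound 4 (0.48 log units; beyond the scatter), a modest step but one beyond the scatter. For the compounds shown here, the only earlier step, a 1.1-fold higher number from compound 1 to compound 2 (0.05 log units; within the scatter), lay within the scatter even though it removed a whole 4-chlorophenyl, so across these two steps, the smaller structural change produced the larger shift in the number. The data shown offer no measurement that accounts for this shift.

From the compounds shown here alone, what remains open is whether the step depends on chloro itself or whether another group on the same aromatic carbon, such as fluoro, methyl or methoxy, would shift the number in the same way. Going by these compounds, it is also open whether the existing chloro is needed for the effect, which a ring carrying only the new chloro would test, and whether an amine or a carboxylic acid at this position would be tolerated.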